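The source may hold more compounds than are shown below. What is called first, only, known or untested is meant among the compounds shown, and "the series" means these compounds.

Going by the values given here, in a physicochemical assay for solubility, read by LC-MS, in phosphate buffer, with a stated time of 24 h, at pH 7.4 (a lower number here means a less soluble compound, a higher number a more soluble compound), compound 2 (`CN(C)Cc1ccc(C(=O)Nc2cnc(NCc3c(F)ccc4c3CCO4)n3cnnc23)cc1`) gives 520000 nM, the highest number of the three measured so far. Compound 4 (`O=C(Nc1cnc(NCc2c(F)ccc3c2CCO3)n2cnnc12)c1ccccc1`) has not been measured and differs from compound 2 by hydrogen in place of (dimethylamino)methyl on an aromatic carbon. Among the compounds with values here, the only measured step, a 2.0-fold lower number from compound 1 to compound 3 (0.30 log units; within the scatter), is a different change on a different core, so it offers little guidance. Neither compound 1 (`Cn1nccc1-c1cnc(NCc2c(F)ccc3c2CCO3)c2cn[nH]c(=O)c12`), at 2000 nM, nor compound 3 (`Cc1cc(-c2cnc(NCc3c(F)ccc4c3CCO4)c3cn[nH]c(=O)c23)n(C)n1`), at 1000 nM, carries the departing group, and on those two values a large step to a lower number is expected in this assay. The estimated step is a 65-fold lower number from compound 2 to compound 4 (1.81 log units; beyond the scatter). For compound 4 the expected value is 8000 nM, with an estimated range of 1500 nM to 40000 nM.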

Compound 4, solubility: 2000 nM
Estimate against measurement, compound 4: 4.0-fold (0.60 log units) above; low and high end bracket the measured number.
By their numbers in this assay, from the lowest: compounds 3, 1 and 4 (each within the scatter of the next); then compound 2.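

In this assay, going by these compounds alone, hydrogen in place of (dimethylamino)methyl, on an aromatic carbon para to a large group, gives a 260-fold lower number from compound 2 to compound 4 (2.41 log units; beyond the scatter), the only step so far that lies beyond the scatter. This position therefore tolerates a change that moves the number greatly, whereas the earlier methyl step on a different core did not. Nothing measured here accounts for the size of this step. As far as these compounds go, whether a morpholine, a piperidine or a carboxylic acid at this position would give a similar number remains open. So does whether the amine nitrogen or the carbon linking it to the ring matters more.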